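The source may report more compounds than this note shows. Statements on the series, on what has been measured and on what is new or still open speak of the compounds shown alone.

Measured in a functional assay on MCF7 cells (Homo sapiens) for inhibition, read by MTT assay, with a stated time of 72 h; a lower number here means a stronger inhibitor, a higher number a weaker inhibitor
Compound 1 `COC(=O)CCCCCCC(=O)Nc1cccc(OS(=O)(=O)C2CC3OC2C(c2ccc(O)cc2)=C3c2ccc(O)cc2)c1` gives 19100 nM
Compound 2 `Cc1ccccc1OS(=O)(=O)C1CC2OC1C(c1ccc(NC(=O)CCCCCCC(=O)O)cc1)=C2c1ccc(O)cc1` gives 7900 nM

Compound 2 stands lowest of the two at 7900 nM and compound 1 lies higher, beyond the scatter. Compound 3 `O=C(O)CCCCCCC(=O)Nc1ccc(C2=C(c3ccc(O)cc3)C3CC(S(=O)(=O)Oc4ccc(F)cc4)C2O3)cc1` keeps the rest of compound 2 and carries 4-fluorophenyl in place of 2-methylphenyl on an oxygen. For the measured compounds named here, no measured step covers this exchange, so no shift beyond the scatter is expected in this assay and no direction can be argued. The estimated move is a 1.1-fold higher number from compound 2 to compound 3 (0.03 log units; within the scatter) and no more than that. For compound 3 the expected value is 8500 nM within an estimated range of 3500 nM to 20000 nM pending measurement.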

Compound 3, half-maximal inhibitory concentration: 24800 nM
Compound 3: the middle estimate sits 2.9-fold (0.47 log units) below what was measured; the measured number lies above the stated range.
By their numbers in this assay, from the lowest: compound 2; then compounds 1 and 3 (each within the scatter of the next).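

In this assay, for the compounds shown here, the aryl group on the oxygen bound to the sulfonyl sulfur proves able to move the read-out: 4-fluorophenyl in place of 2-methylphenyl gives a 3.1-fold higher number from compound 2 to compound 3 (0.50 log units; beyond the scatter) and this is the first reading at this position. The two groups have the same heavy-atom count and the same hydrogen-bond donor and acceptor counts, so the step arises with those counts unchanged. No measured data on the compounds bear on the origin of this step.

The exchange alters both the substituent and its ring position, so a single step cannot separate the two. On these data alone, whether the methyl or the fluorine matters more remains open, and 4-methylphenyl, 2-fluorophenyl and unsubstituted phenyl on this oxygen would address that question.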